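The source may hold more compounds than are shown below. What is called first, only, known or untested is meant among the compounds shown, and "the series" means these compounds.

In a functional assay on T47D cells (Homo sapiens) for cytotoxicity, with a stated time of 72 h, tested at 50 ug/mL (on this read-out lower numbers stand for a weaker effect and higher numbers for a stronger effect at the one concentration tested), compound 3 `COc1ccc(N2CCN/C2=N\N)cc1` gives 23%. Compound 1 `N/N=C1\NCCN1c1ccccc1Cl` gives 27% in this assay, and compound 2 `Cc1ccc(N2CCN/C2=N\N)cc1` gives 17%; both of these numbers fall within the scatter of the number for compound 3, so the three compounds cannot be told apart on this read-out. Compound 4 `N/N=C1\NCCN1c1ccccc1` differs from compound 3 by hydrogen in place of methoxy on an aromatic carbon. Among the compounds with values here, the only measured step that bears on this change, a number 6 percentage points higher from compound 2 to compound 3 (within the scatter), also exchanged one group on an aromatic carbon and stayed within the scatter. Within the data shown here, no measured compound shows a group at this place shifting the read-out beyond the scatter. The step of a number 1 percentage points lower from compound 3 to compound 4 (within the scatter) is therefore expected to stay within the scatter. Compound 4 is estimated at 22%, with a range from 10% to 34%.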

Compound 4, a percentage reported as inhibition, at one concentration (the size of the read-out at that concentration, not a potency): 0%
Compound 4: the middle estimate sits 22 percentage points above what was measured; measured number below the stated range.
By their numbers in this assay, from the lowest: compound 4; then compounds 2, 3 and 1 (each within the scatter of the next).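

Hydrogen on the aromatic carbon proves to be the one change here that moves the read-out in this assay: a number 23 percentage points lower from compound 3 to compound 4 (beyond the scatter), a number 17 percentage points lower from compound 2 to compound 4 (beyond the scatter) and a number 27 percentage points lower from compound 1 to compound 4 (beyond the scatter). Methoxy, methyl and chloro cannot be told apart from one another, yet each gives a higher number than hydrogen, something the exchange of one group for another had not shown. Nothing available explains this difference. Going by these compounds, it remains open whether an amine or a carboxylic acid on this carbon would also lift the read-out above that of compound 4.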